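Sulfonyl versus methyl on the core nitrogen

The compounds below may be only part of what the source reports. "The series", "measured", "known", "first", "only" and "open" are said of these compounds alone.

Measured compounds in a functional assay on SUP-B15 cells (Homo sapiens) for antiproliferative activity, with a stated time of 72 h; a lower number here means that less compound is needed, a higher number that more compound is needed for the effect:
compound 1 `COc1ccc(-c2cc(=O)c3c(OC)cc(OC)cc3n2C)cc1`: 28000 nM
compound 2 `C=CCNC(=O)n1c(-c2ccc(OC)cc2)cc(=O)c2c(OC)cc(OC)cc21`: 16000 nM
compound 3 `COc1ccc(-c2cc(=O)c3c(OC)cc(OC)cc3n2S(=O)(=O)c2cccc([N+](=O)[O-])c2)cc1`: > 39600 nM

Compound 1 stands highest of the two numbers; its nearest neighbour is compound 2, and a 1.8-fold lower number from compound 1 to compound 2 (0.24 log units; within the scatter). For compound 3 the result is a limit, (the limit of > 39600 nM in this assay, at which 1 of the 3 values shown sits), not a number. Compound 4 `COc1ccc(-c2cc(=O)c3c(OC)cc(OC)cc3n2S(=O)(=O)c2ccc(Br)cc2)cc1` is not yet measured; it differs from compound 1 by (4-bromophenyl)sulfonyl in place of methyl on an aromatic nitrogen. Among the measured compounds shown here, no measured step covers this change directly. Compound 3, which also carries a sulfonyl on the same nitrogen, returned only a limit, so a number is expected no lower than that of compound 1 and possibly again a limit. The expectation for compound 4 is 38000 nM, between 16000 nM and 90000 nM, which means a 1.4-fold higher number from compound 1 to compound 4 (0.13 log units; within the scatter).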

Compound 4, half-maximal effective concentration: 63800 nM
Estimate against measurement, compound 4: 1.7-fold (0.23 log units) below, within the range that was stated.
By their numbers in this assay, from the lowest: compounds 2 and 1 (each within the scatter of the next); then compound 4.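

In this assay, a sulfonyl group on the aromatic nitrogen now has a readable number: (4-bromophenyl)sulfonyl in place of methyl gives a 2.3-fold higher number from compound 1 to compound 4 (0.36 log units; beyond the scatter). The same group in place of allylcarbamoyl gives a 4.0-fold higher number from compound 2 to compound 4 (0.60 log units; beyond the scatter), so this position separates compound 4 from both, while compound 1 and compound 2 lie within the scatter of each other. The step from compound 3 cannot be read, since compound 3 gives only a limit: the limit of > 39600 nM in this assay, at which 1 of the 4 values shown sits.

The compounds shown leave open whether the aryl group on the sulfur matters at all. Also open, on these data alone, is how a methanesulfonyl group, or an amine on that phenyl ring, would read.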